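Fluoro for trifluoromethoxy on the shared core

The source may report more compounds than this note shows. Statements on the series, on what has been measured and on what is new or still open speak of the compounds shown alone.

Measured compounds in a functional assay on HCT-116 cells (Homo sapiens) for inhibition, read by sulforhodamine B assay, with a stated time of 72 h; a lower number here means a stronger inhibitor, a higher number a weaker inhibitor:
Compound 1, `CC(c1ccc(-c2ccccc2)c(F)c1)c1nnc2n1N=C(c1ccc(OC(F)(F)F)cc1)CS2`, gives 5400 nM.
Compound 2, `CC(C)Cc1ccc(C(C)c2nnc3n2N=C(c2ccc(C(F)(F)F)cc2)CS3)cc1`, gives 6500 nM.
Compound 3, `CC(C)Cc1ccc(C(C)c2nnc3n2N=C(c2ccc(F)cc2)CS3)cc1`, gives 12400 nM.

Compound 1 and compound 2 lie within the scatter of each other, while compound 3 stands above compound 1 by more than the scatter. Compound 4, `CC(c1ccc(-c2ccccc2)c(F)c1)c1nnc2n1N=C(c1ccc(F)cc1)CS2`, differs from compound 1 by fluoro in place of trifluoromethoxy on an aromatic carbon. Going by the values given here, one measured step bears on this change, at the same place on the same ring, with trifluoromethyl rather than trifluoromethoxy leaving: a 1.9-fold higher number from compound 2 to compound 3 (0.28 log units; within the scatter). A step of similar size, toward a higher number, is therefore expected here, although it may not exceed the scatter: a 1.7-fold higher number from compound 1 to compound 4 (0.22 log units; within the scatter) is the expected step. Compound 4 is estimated at 9000 nM, with a range from 4000 nM to 20000 nM.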

Compound 4, half-maximal inhibitory concentration: 10500 nM
The estimate for compound 4 lay 1.2-fold (0.07 log units) below the measured number, and the stated range covers the measured number.
By their numbers in this assay, from the lowest: compounds 1, 2, 4 and 3 (each within the scatter of the next, the first and the last beyond it).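

In this assay, fluoro in place of trifluoromethoxy on an aromatic carbon, para to a large group, gives a 1.9-fold higher number from compound 1 to compound 4 (0.29 log units; within the scatter) and so stays within the scatter. Read with a 1.9-fold higher number from compound 2 to compound 3 (0.28 log units; within the scatter), this shows the same outcome at this place with two different groups elsewhere on the shared core, both steps pointing to a higher number. No measurement on hand accounts for either step.

As far as these compounds go, whether an amine, a carboxylic acid or a longer chain at this place would give a step beyond the scatter remains open.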